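Adding a fluorine to a weakly active benzothiazole

The compounds below may be only part of what the source reports. "The series", "measured", "known", "first", "only" and "open" are said of these compounds alone.

Compound 1, `COc1ccc(-c2nc3ccccc3s2)cc1OC`, was tested in a functional assay on MCF7 cells (Homo sapiens) for inhibition; on this read-out lower numbers stand for stronger inhibition and higher numbers for weaker inhibition. In this assay compound 1 gives 52700 nM, the highest of the three measured numbers. Compound 2, `COc1ccc(-c2nc3cc(F)ccc3s2)cc1`, gives 490 nM, and compound 3, `COc1ccc(-c2nc3cc(F)ccc3s2)cc1F`, gives 870 nM. The difference between the core of compound 1 and the core of compound 2 is not broken down here.

Compound 2 and compound 3 differ in one place: fluoro in place of hydrogen on an aromatic carbon. This change gave a 1.8-fold higher number from compound 2 to compound 3 (0.25 log units; within the scatter).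

Compound 4, `COc1ccc(-c2nc3ccc(F)cc3s2)cc1OC`, has not yet been measured. It differs from compound 1 by fluoro in place of hydrogen on an aromatic carbon. This is the same kind of change as from compound 2 to compound 3, not the same change: there the fluorine sits ortho to a methoxy group and meta to a large group, here it sits meta to a fused ring and para to a fused ring, on a ring that is part of a fused system.

Because the earlier change gave a 1.8-fold higher number from compound 2 to compound 3 (0.25 log units; within the scatter), a similarly small step is expected for compound 4, a 1.3-fold lower number from compound 1 to compound 4 (0.12 log units; within the scatter). Compound 4 is therefore estimated at 40000 nM, between 10000 nM and 150000 nM.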

Compound 4, half-maximal inhibitory concentration: 62 nM
Compound 4: the middle estimate sits 650-fold (2.81 log units) above what was measured; measured number outside the range, below it.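

In this assay, fluoro in place of hydrogen on an aromatic carbon of a fused system of two rings gave an 850-fold lower number from compound 1 to compound 4 (2.93 log units; beyond the scatter), so swapping a single hydrogen can matter a great deal in this series. Set beside the earlier step, the size of this change clearly did not carry over from one core to the other: the same change on two cores in this assay, a 1.8-fold higher number (0.25 log units; within the scatter) from compound 2 to compound 3 and an 850-fold lower number (2.93 log units; beyond the scatter) from compound 1 to compound 4, 1500-fold (3.18 log units) apart, beyond the scatter of two such steps. What this does not show is why the two steps differ, since the fluoro stands at a different place on a different core in each pair, and two pairs cannot separate the effect of the core from the effect of the place or give a rule for the whole series.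

The compounds shown leave open whether the large step belongs to fluoro itself or would also appear with a chloro, a methyl or an amine on the same carbon. They also leave open what fluoro would do on the other aromatic carbons of that ring in the core of compound 1.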